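The source may report more compounds than this note shows. Statements on the series, on what has been measured and on what is new or still open speak of the compounds shown alone.

In a functional assay on SiHa cells (Homo sapiens) for inhibition, read by sulforhodamine B assay (on this read-out higher numbers stand for weaker inhibition of growth and lower numbers for stronger inhibition of growth), compound 1 (`COc1ccc(-c2ccc(-c3ccc(-c4nc5cc(C)ccc5[nH]4)cc3)cc2)cc1OC`) gives 3510 nM and compound 2 (`COc1cc(-c2ccc(-c3ccc(-c4nc5cc(C)ccc5[nH]4)cc3)cc2)cc(OC)c1OC`) gives 170 nM, the lower of the two numbers. For the measured compounds named here, the one measured step, a 21-fold lower number from compound 1 to compound 2 (1.31 log units; beyond the scatter), comes with methoxy in place of hydrogen on an aromatic carbon. Compound 3 (`COc1cc(-c2ccc(-c3ccc(-c4nc5c(O)cccc5[nH]4)cc3)cc2)cc(OC)c1OC`) keeps that methoxy group of compound 2 and changes elsewhere, with 4-hydroxy-1H-benzimidazol-2-yl in place of 5-methyl-1H-benzimidazol-2-yl on an aromatic carbon. Going by the values given here, no measured step touches this group, so the data give no direct guide to its size or direction. The step to compound 2 bears on it only indirectly, showing that a single change here can move the number widely: a 21-fold lower number from compound 1 to compound 2 (1.31 log units; beyond the scatter). No step beyond the scatter is therefore expected in this assay, though the range must stay wide. Compound 3 is expected at 250 nM, with an estimated range of 60 nM to 1000 nM. The expected change is a 1.5-fold higher number from compound 2 to compound 3 (0.17 log units; within the scatter).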

Compound 3, concentration for 50% growth inhibition: 170 nM
Compound 3: the middle estimate sits 1.5-fold (0.17 log units) above what was measured; measured number inside the range.
By their numbers in this assay, from the lowest: compounds 2 and 3 (each within the scatter of the next); then compound 1.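

In this assay, for the compounds shown here, 4-hydroxy-1H-benzimidazol-2-yl in place of 5-methyl-1H-benzimidazol-2-yl gives no change at the digits printed from compound 2 to compound 3 (within the scatter), so this group can be exchanged without a step beyond the scatter, whereas the one earlier step, a 21-fold lower number from compound 1 to compound 2 (1.31 log units; beyond the scatter), showed only that a methoxy change elsewhere moves the number widely. Because the methyl leaves and the hydroxy enters at differently numbered places in a single step, the result cannot say whether neither change matters or whether two opposing contributions cancel. Nothing available here explains why the number holds.

As far as these compounds go, it remains open whether an amine or a carboxylic acid in place of the hydroxy would keep the number. Also open, from the compounds shown here alone, is whether the same exchange would leave the number of compound 1 as undisturbed.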